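This account rests on a few compounds, and the source may have more. Where it says the series, first, only, none or still open, it means among the compounds named here.

Of the compounds shown here, two have numbers so far. In a physicochemical assay for solubility, read by HPLC, in phosphate buffer, measured as kinetic solubility, at pH 7.4 (a higher number here means a more soluble compound, a lower number a less soluble compound), compound 1 (`Cc1ccc(-c2ccc(Cl)cc2)n1-c1ccc(S(N)(=O)=O)cc1`) gives 6100 nM and compound 2 (`CCC(=O)c1cc(-c2ccccc2)n(-c2ccc(S(N)(=O)=O)cc2)c1C`) gives 14100 nM as the higher of the two numbers. That gap lies beyond the usual scatter of the measurement, but the two structures differ in more than one place, so no single change can be read from it.

The next compound is compound 3 (`CCC(=O)c1cc(-c2ccccc2Cl)n(-c2ccc(S(N)(=O)=O)cc2)c1C`), which differs from compound 2 in one place only: chloro in place of hydrogen on an aromatic carbon (chloro in place of hydrogen on an aromatic carbon, ortho to a large group). Phenyl thus becomes 2-chlorophenyl. For the measured compounds named here, no measured pair isolates this change, so the expectation rests on the structural change alone and stays loose. A modest step downward in this assay is expected, of a size that may not clear the scatter. The estimated change is a 1.8-fold lower number from compound 2 to compound 3 (0.25 log units; within the scatter) and this is a working expectation only. Compound 3 is expected at 8000 nM (estimated range 3000 nM to 16000 nM).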

Compound 3, solubility: 38200 nM
Compound 3: middle estimate off by 4.8-fold (0.68 log units), on the low side; measured number above the stated range.
By their numbers in this assay, from the lowest: compound 1; then compound 2; then compound 3.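

In this assay the series now has its first step that can be read at a single place: chloro in place of hydrogen on an aromatic carbon, ortho to a large group, gives a 2.7-fold higher number from compound 2 to compound 3 (0.43 log units; beyond the scatter) and turns phenyl into 2-chlorophenyl. This pair shows that adding one heavy atom at this place does not have to lower the number, since the step runs upward and stands clear of the usual scatter, which the two earlier compounds could not show because they differ in more than one place. Nothing available on the series accounts for the rise, so it stands as an observation from a single pair.

Which groups at this same place on the aromatic ring share the upward step remains open, whether fluoro, methyl, methoxy or an amine, and so does whether it belongs to chloro alone. Also open, going by these compounds, is whether chloro elsewhere on that ring, or the same change on the core of compound 1, would move the number in the same direction.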